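Cyclohexyl in Place of Phenethyl on the Side Chain

A few compounds are considered here, and "the series" means these few. Any claim that something is new, unique, unknown or untested is made for them only; others in the source may bear on it.

Compound 1 `Cc1nc(N)sc1CCCN/C(N)=N/C(=O)NCC(C)CCc1ccccc1` was tested in an assay on membranes from Sf9 cells for displacement of a labelled ligand from histamine H2 receptor (Homo sapiens), read by scintillation counting, with a stated time of 60 min (a higher number here means a weaker inhibitor, a lower number a stronger inhibitor), where compound 1 gives 63.1 nM. Of the three compounds measured, compound 1 carries the highest number. Compound 2 `Cc1nc(N)sc1CCCN/C(N)=N/C(=O)NC(c1ccccc1)C(C)C` gives 35.5 nM in this assay, and this gap from compound 1 lies within the scatter, so the two cannot be ordered. Compound 3 `Cc1nc(N)sc1CCCN/C(N)=N/C(=O)NC(C)c1ccccc1F` gives 28.8 nM in this assay, a gap beyond the scatter, so compound 3 is the stronger inhibitor of that pair. For the measured compounds named here, no two measured compounds differ in one place only, so no single step is known.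

Compound 4 `Cc1nc(N)sc1CCCN/C(N)=N/C(=O)NCC(C)C1CCCCC1` has not yet been measured. It differs from compound 1 by cyclohexyl in place of phenethyl on a saturated chain carbon bound to two saturated chain carbons. The measured compounds give no guide to this change, as compound 2 and compound 3 each differ from compound 1 in more than one place. The expected step is a 1.3-fold higher number from compound 1 to compound 4 (0.10 log units; within the scatter), small and in no direction that clears the scatter. Compound 4 is therefore estimated at 80 nM, expected to fall between 30 nM and 250 nM.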

Compound 4, inhibition constant: 39.8 nM
Compound 4: middle estimate off by 2.0-fold (0.30 log units), on the high side; measured number inside the range.
By their numbers in this assay, from the lowest: compounds 3, 2, 4 and 1 (each within the scatter of the next, the first and the last beyond it).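

This gives the series its first single step: in this assay, cyclohexyl in place of phenethyl on a saturated chain carbon bound to two saturated chain carbons gives a 1.6-fold lower number from compound 1 to compound 4 (0.20 log units; within the scatter) and lies within the scatter, so compound 1 and compound 4 cannot be ordered. At this place, then, the phenethyl group with its aromatic ring can give way to cyclohexyl, which has fewer heavy atoms and a non-aromatic ring, without a step that clears the scatter. No measurement at hand bears on why the two compounds read alike.

As far as these compounds go, it remains open whether phenyl bound directly at this carbon, a cyclopentyl ring or a piperidine ring would also stay within the scatter of compound 1. Whether a longer chain ending in cyclohexyl would do so is equally unsettled, as is whether the same exchange would give a similar step on other side chains.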